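This account rests on a few compounds, and the source may have more. Where it says the series, first, only, none or still open, it means among the compounds named here.

For the measured compounds named here, in a functional assay on HeLa cells (Homo sapiens) for cytotoxicity, read by MTT assay, with a stated time of 48 h (on this read-out lower numbers stand for stronger inhibition and higher numbers for weaker inhibition), compound 1 (`COc1cc([C@@H]2C[C@@]2(CO)C(=O)Nc2ccccc2)cc(OC)c1OC`) gives 86400 nM and is the only compound of the three with an actual number. Compound 2 (`COc1cc([C@H]2C[C@@]2(CO)C(=O)Nc2ccccc2)cc(OC)c1OC`) reads > 100000 nM, which is a limit of the assay and not a number. Compound 3 (`COc1cc([C@H]2C[C@]2(CO)C(=O)Nc2ccccc2)cc(OC)c1OC`) reads > 100000 nM, again a limit and not a number.

Compound 4 (`COc1cc([C@@H]2C[C@@]2(CO)C(=O)Nc2ccccc2Cl)cc(OC)c1OC`) has chloro in place of hydrogen on an aromatic carbon, ortho to a large group, so that phenyl becomes 2-chlorophenyl (chloro in place of hydrogen on an aromatic carbon). Both an at least 1.1-fold higher number from compound 1 to compound 2 (0.06 log units; that floor lies within the scatter) and an at least 1.1-fold higher number from compound 1 to compound 3 (0.06 log units; that floor lies within the scatter) are changes of configuration alone, and neither floor goes beyond the scatter. Going by the values given here, no measured step tests a chloro group, so the expectation rests only on compound 1 at 86400 nM as a starting point. In this assay, on these data alone, no step beyond the scatter is expected, and either direction remains open. The expected size is a 1.2-fold lower number from compound 1 to compound 4 (0.09 log units; within the scatter) by estimate, with weak inhibition remaining. The estimated value for compound 4 is 70000 nM with an expected range from 25000 nM to 140000 nM in this assay's read-out.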

Compound 4, half-maximal inhibitory concentration: 13300 nM
Beside the measured number, compound 4's estimate is 5.3-fold (0.72 log units) above it, and the stated range ends above it.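

In this assay, for the compounds shown here, putting chloro in place of hydrogen on the phenyl ring gives the first step in this set that is clearly beyond the scatter, a 6.5-fold lower number from compound 1 to compound 4 (0.81 log units; beyond the scatter). The changes of configuration among compounds 1, 2 and 3 gave only floors within the scatter, whereas this single added atom shows that the read-out does respond to a change at this place on the ring, though the step is modest. Nothing shown explains why chloro has this effect.

On these data alone, it remains open whether fluoro, methyl, methoxy or an amine at this place would move the number in the same direction, and whether chloro elsewhere on the ring would do so. As far as these compounds go, it is also open whether the 2-chlorophenyl group would have a similar effect in the configurations of compound 2 and compound 3.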